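Benzimidazolyl to pyridinyl on the shared core of compound 1

This account rests on a few compounds, and the source may have more. Where it says the series, first, only, none or still open, it means among the compounds named here.

Measured compounds:
compound 1, `CCN(c1ccc(C#N)c(Cl)c1)c1cc(-n2cnc3ccccc32)ccc1C`, 8160 nM
compound 2, `N#Cc1ccc(N2CCc3cc(-c4cncnc4)ccc3C2)cc1C(F)(F)F`, "not determined" (no result reported)
compound 3, `CCN(c1ccc(C#N)c(C(F)(F)F)c1)c1cc(-n2ccnc2)ccc1C`, > 30000 nM

Among the compounds with values here, in a functional assay on PC-3 cells (Homo sapiens) for antiproliferative activity, read by CCK-8 assay, with a stated time of 6 days (a lower number here means a stronger inhibitor, a higher number a weaker inhibitor), compound 1 gives 8160 nM, the only plain number among the three entries. For compound 3 the result is a limit, > 30000 nM, so compound 3 stands at the limit of > 30000 nM in this assay, at which 1 of the 3 values shown sits. For compound 2 no number is given in this assay. Within the data shown here, with only one number and one limit, no step between measured compounds can be read, and nothing is known here about how these compounds bind.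

Compound 4, `CCN(c1ccc(C#N)c(Cl)c1)c1cc(-c2cccnc2)ccc1C`, differs from compound 1 by pyridin-3-yl in place of 1H-benzimidazol-1-yl on an aromatic carbon. Among the measured compounds shown here, since no measured pair shows what this exchange does, the step from compound 1 to compound 4 in this assay is expected to be small, no more than the usual scatter, in either direction. Compound 4 is therefore expected to give about 10000 nM in this assay, within 3000 nM to 30000 nM, which means an expected step of a 1.2-fold higher number from compound 1 to compound 4 (0.09 log units; within the scatter).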

Compound 4, half-maximal inhibitory concentration: 11000 nM
Compound 4: middle estimate off by 1.1-fold (0.04 log units), on the low side; the measured number falls inside the stated range.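

In this assay the exchange of 1H-benzimidazol-1-yl for pyridin-3-yl gives a 1.3-fold higher number from compound 1 to compound 4 (0.13 log units; within the scatter) and is the first step that can be read among these compounds. On this aromatic carbon, para to a methyl group and meta to a large group, a single six-membered aromatic ring with one hetero atom thus takes the place of a five-membered and a six-membered aromatic ring without moving the number beyond the scatter. This holds for this one pair on the shared core, and it says nothing yet about other groups at this place.

As far as these compounds go, whether an amine, a carboxylic acid or a longer chain on this carbon would move the number beyond the scatter remains open. Nothing shown gives a cause for this step.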